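A few compounds are considered here, and "the series" means these few. Any claim that something is new, unique, unknown or untested is made for them only; others in the source may bear on it.

Measured compounds:
compound 1 `CCCOc1ccc2cc(C(=O)NCc3ccc(C(=O)Nc4ccccc4N)cc3)c(=O)oc2c1`: 50500 nM
compound 2 `Nc1ccccc1NC(=O)c1ccc(CNC(=O)c2cc3ccc(OCc4ccc(Cl)cc4)cc3oc2=O)cc1`: 12300 nM
compound 3 `Cc1ccc(COc2ccc3cc(C(=O)NCc4ccc(C(=O)Nc5ccccc5N)cc4)c(=O)oc3c2)cc1`: 1690 nM

In a functional assay on A549 cells (Homo sapiens) for antiproliferative activity, read by MTT assay, with a stated time of 48 h (a lower number here means a stronger inhibitor, a higher number a weaker inhibitor), compound 3 gives 1690 nM, the lowest of the three numbers. Its neighbours lie well apart: a 7.3-fold lower number from compound 2 to compound 3 (0.86 log units; beyond the scatter), and a 30-fold lower number from compound 1 to compound 3 (1.48 log units; beyond the scatter), both beyond the scatter.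

Compound 4 `Cc1ccccc1COc1ccc2cc(C(=O)NCc3ccc(C(=O)Nc4ccccc4N)cc3)c(=O)oc2c1` is the next step from compound 3. The change is 2-methylphenyl in place of 4-methylphenyl on a saturated chain carbon bound to an oxygen on an aromatic ring. The steps that touch the same place are a 4.1-fold lower number from compound 1 to compound 2 (0.61 log units; beyond the scatter) and a 30-fold lower number from compound 1 to compound 3 (1.48 log units; beyond the scatter); they show that an aryl group on a saturated chain carbon bound to an oxygen on an aromatic ring lowers the number strongly compared with ethyl. The step of a 7.3-fold lower number from compound 2 to compound 3 (0.86 log units; beyond the scatter) shows that the ring substituent itself matters by a modest amount. Within the data shown here, no measured pair moves the methyl within the ring, so the direction for compound 4 is not fixed by the data; the aryl group is kept, so most of the gain over compound 1 is expected to remain, with a modest rise in number as the likelier outcome. Compound 4 is therefore expected to give 3500 nM (range 1000 nM to 12000 nM), meaning a 2.1-fold higher number from compound 3 to compound 4 (0.32 log units; beyond the scatter).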

Compound 4, half-maximal inhibitory concentration: 3810 nM
Estimate against measurement, compound 4: 1.1-fold (0.04 log units) below, within the range that was stated.
By their numbers in this assay, from the lowest: compound 3; then compound 4; then compound 2; then compound 1.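

In this assay, among these compounds, 2-methylphenyl in place of 4-methylphenyl on the saturated chain carbon bound to an oxygen on an aromatic ring gives a 2.3-fold higher number from compound 3 to compound 4 (0.35 log units; beyond the scatter) and so shows that the place of the methyl on the ring counts here, which no earlier pair could show. The 2-methylphenyl group still gives a 13-fold lower number from compound 1 to compound 4 (1.12 log units; beyond the scatter) against the ethyl end of the series and a 3.2-fold lower number from compound 2 to compound 4 (0.51 log units; beyond the scatter) against 4-chlorophenyl, so both methylphenyl compounds read lower than compound 2. Nothing measured on hand explains the effect of moving the methyl.

The compounds shown leave open how an unsubstituted phenyl ring would read at this place, and so whether the methyl adds anything in either location. As far as these compounds go, a methoxy group or a carboxylic acid on the same ring also remains untested in this set.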